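Benzofuran to indole at the carbonyl in compound 1

The compounds below may be only part of what the source reports. "The series", "measured", "known", "first", "only" and "open" are said of these compounds alone.

Measured compounds:
Compound 1 `COc1cccc(CN2C(=O)CN(C(=O)c3cc4cc(OC)ccc4o3)C[C@@H]2CCc2ccccc2)c1`: 4500 nM
Compound 2 `O=C(c1cc2cc(C3CC3)ccc2[nH]1)N1CC(=O)N(Cc2ccccc2)[C@@H](CN2CCC(F)CC2)C1`: 24500 nM
Compound 3 `COc1ccc2[nH]c(C(=O)N3CC(=O)N(Cc4ccc[nH]4)[C@@H](Cc4ccccc4)C3)cc2c1`: 15200 nM

In an ADME assay on Vero cells (Chlorocebus sabaeus) for cytotoxicity, with a stated time of 7 days (a higher number here means that more compound is tolerated, a lower number that less compound is tolerated), compound 1 gives 4500 nM, the lowest of the three numbers shown. Compound 3 stands closest to it, with a number beyond the scatter above that of compound 1, and compound 2 lies furthest away, also beyond the scatter. Going by the values given here, no pair among the three differs in a single place, so no step between measured compounds can be read off.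

Compound 4 `COc1cccc(CN2C(=O)CN(C(=O)c3cc4cc(OC)ccc4[nH]3)C[C@@H]2CCc2ccccc2)c1` has not yet been measured in this assay. It differs from compound 1 in one place: 5-methoxy-1H-indol-2-yl in place of 5-methoxy-1-benzofuran-2-yl on a carbonyl carbon. The change swaps one hetero atom for another in the same five-membered aromatic ring and trades one hydrogen-bond acceptor for a hydrogen-bond donor, while the heavy-atom count stays the same.

Since the other two compounds, both carrying an amide-type ring nitrogen linked to a related bicyclic carbonyl partner, give higher numbers than compound 1, a modest rise from compound 1 to compound 4 is expected, though it may not exceed the scatter; the expected step is a 1.6-fold higher number from compound 1 to compound 4 (0.19 log units; within the scatter). For compound 4 the estimate is 7000 nM, within a range from 3000 nM to 16000 nM.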

Compound 4, half-maximal cytotoxic concentration: 4500 nM
Compound 4: middle estimate off by 1.6-fold (0.19 log units), on the high side; low and high end bracket the measured number.
By their numbers in this assay, from the lowest: compounds 1 and 4 (each within the scatter of the next); then compounds 3 and 2 (each within the scatter of the next).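

In this assay, putting 5-methoxy-1H-indol-2-yl in place of 5-methoxy-1-benzofuran-2-yl on a carbonyl carbon gives no change at the digits printed from compound 1 to compound 4 (within the scatter). Going by these compounds alone, this is the first step in the set that can be read in a single place, and it shows that, on this carbonyl carbon in the core of compound 1, exchanging one hetero atom of the five-membered aromatic ring for another, with a hydrogen-bond donor entering and a hydrogen-bond acceptor leaving, does not register in this read-out. Nothing available accounts for this outcome.

The compounds shown leave open whether this position tolerates any larger departure in this assay, such as a carboxylic acid in place of the methoxy group on the 5-methoxy-1H-indol-2-yl group. Within the data shown here, the other parts of compound 1 remain unread, since no single-place step touches them.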